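A few compounds are considered here, and "the series" means these few. Any claim that something is new, unique, unknown or untested is made for them only; others in the source may bear on it.

Measured so far:
Compound 1 `O=[N+]([O-])c1ccc(NC(=S)NCCNS(=O)(=O)c2ccc(-c3ccccc3O[C@H]3CC[C@@H](O)CC3)s2)cc1` gives > 20000 nM in a functional assay on HeLa cells (Homo sapiens) for inhibition, read by CCK-8 assay, with a stated time of 48 h (a higher number here means a weaker inhibitor, a lower number a stronger inhibitor), which is a limit of the assay and not a number.
Compound 2 `COc1ccc(Oc2ccc(C(C)C)cc2-c2ccsc2S(=O)(=O)NCCNC(=O)Nc2cc(Cl)cc(Cl)c2)cc1OC` gives 11600 nM in this assay.
Compound 3 `O=C(NCCNS(=O)(=O)c1ccc(-c2ccccc2Oc2ccc([N+](=O)[O-])c([N+](=O)[O-])c2)s1)Nc1cc(Cl)cc(Cl)c1` gives > 20000 nM in this assay, again a limit of the assay.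

Compound 1 therefore stands at the limit of > 20000 nM in this assay, at which 2 of the 3 values shown sit, and nothing more precise is known of it. Compound 4 `O=[N+]([O-])c1ccc(NC(=S)NCCNS(=O)(=O)c2ccc(-c3ccccc3O[C@H]3CC[C@H](O)CC3)s2)cc1` is to be measured in this assay. It differs from compound 1 in configuration only: the two compounds have the same atoms and bonds and differ only in configuration as drawn: 2 of 2 stereo elements differ (all stereocentres are inverted: mirror images); a stereocentre at a saturated ring carbon is drawn s in compound 1 and r in compound 4; a stereocentre at a saturated ring carbon is drawn s in compound 1 and r in compound 4. No step between measured compounds is shown, so there is no measured guide to what such an inversion does here. The expectation is that the result stays near the limit, with no step beyond the scatter: the step estimated from compound 1 to compound 4 is a number no higher from compound 1 to compound 4 (the limit leaves the size open). Compound 4 is expected to give about 20000 nM, within a range from 8000 nM to 60000 nM.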

Compound 4, half-maximal inhibitory concentration: 5400 nM
Estimate against measurement, compound 4: 3.7-fold (0.57 log units) above; the measured number lies below the stated range.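

In this assay, inverting both stereocentres on the saturated ring leaves atoms and bonds unchanged yet gives an at least 3.7-fold lower number from compound 1 to compound 4 (0.56 log units; beyond the scatter), so this position responds to configuration alone. On these data alone, compound 1 gives > 20000 nM, which is a limit of the assay and not a number, so the full size of the step remains unknown. No earlier pair isolated such a change, and here nothing else can account for the step: the fact that compounds 1 and 4 differ only in the configuration as drawn

As far as these compounds go, what remains open is whether the hydroxyl group on that ring matters in either configuration. It is also unknown how an amine or a carboxylic acid there would read in this assay.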